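The source may hold more compounds than are shown below. What is called first, only, known or untested is meant among the compounds shown, and "the series" means these compounds.

In a functional assay on CHO cells for agonist activity at prostaglandin E2 receptor EP4 subtype (Homo sapiens), read by HTRF and cAMP accumulation, with a stated time of 30 min (a higher number here means that more compound is needed for the effect, a lower number that less compound is needed), compound 2 (`O=C(O)c1csc([C@H]2CC[C@@H]3[C@@H](COc4ccccc4)[C@H](O)C[C@@H]3O2)n1`) does not reach a measured number: its result, > 10000 nM, is a limit of the assay. It shares this with compound 1 (`O=C(O)c1csc([C@H]2CC[C@@H]3[C@@H](/C=C/COc4ccccc4)[C@H](O)C[C@@H]3O2)n1`), whose result > 10000 nM is likewise a limit. Both sit at the limit of > 10000 nM in this assay, at which 2 of the 3 values shown sit. Within the data shown here, the only compound with an actual number is compound 3 (`O=C(O)CCC[C@H]1CC[C@@H]2[C@@H](/C=C/[C@@H](O)COc3ccccc3)[C@H](O)C[C@@H]2O1`), which in this assay gives 4600 nM; it differs from the other two in several places at once, so no single step can be drawn from it.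

Among the measured compounds shown here, compound 4 (`O=C(O)c1csc([C@H]2CC[C@@H]3[C@@H](CCOc4ccccc4)[C@H](O)C[C@@H]3O2)n1`) is the one compound still to be measured. It differs from compound 2 by phenoxymethyl in place of phenoxy on a saturated chain carbon bound to a saturated ring carbon, so the side chain grows by one carbon. For the measured compounds named here, no step between measured compounds that differ in just one place is on hand, so the size of the expected change rests on the fact that compound 2 is already at a limit and that compound 3, the one numbered compound, is weak. The step expected here, an at least 1.1-fold lower number from compound 2 to compound 4 (0.04 log units; that floor lies within the scatter), is therefore estimated as small, with no clear direction beyond the scatter. Compound 4 is expected to give about 9000 nM in this assay, within a range from 2500 nM to 30000 nM.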

Compound 4, half-maximal effective concentration: > 10000 nM
Compound 4: a limit, no number; the forecaster's own chance of this, stated with the estimate: 55%; at least 1.1-fold (0.04 log units) between middle value and limit.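

Compound 4 gives > 10000 nM in this assay, which is a limit of the assay and not a number. Compound 2 also stands at a limit, so no step can be read between these two compounds: the limit of > 10000 nM in this assay, at which 3 of the 4 values shown sit.

The compounds shown leave open whether phenoxymethyl in place of phenoxy changes the response in this assay at all.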